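Trimming a Dimethylamide Back to a Primary Amide

The compounds below may be only part of what the source reports. "The series", "measured", "known", "first", "only" and "open" are said of these compounds alone.

Compound 1 `CNC(=O)c1cc(OCCCCOc2ccc(C(=O)CC(C)(C)C)c(O)c2C)ccc1F`: 476 nM
Compound 2 `COc1ccc(OCCCCOc2ccc(C(=O)CC(C)(C)C)c(O)c2C)cc1`: "not active" (no number reported)
Compound 3 `Cc1c(OCCCCOc2ccc(F)c(C(=O)N(C)C)c2)ccc(C(=O)CC(C)(C)C)c1O`: "not active" (no number reported)

In an assay for positive allosteric modulation of metabotropic glutamate receptor 3 (Rattus norvegicus) (on this read-out lower numbers stand for an effect already at smaller amounts and higher numbers for an effect only at larger amounts of compound), compound 1 gives 476 nM. Compound 2 is reported as "not active" (no number reported) in this assay, and compound 3 likewise as "not active" (no number reported), so compound 3 stands without a single number, one of two such entries. Compound 4 `Cc1c(OCCCCOc2ccc(F)c(C(N)=O)c2)ccc(C(=O)CC(C)(C)C)c1O` is not yet measured. It differs from compound 3 in one place: amino in place of dimethylamino on a carbonyl carbon. Among the compounds with values here, no step between measured compounds has been reported, so the size of this step is unknown; compound 1 shows that an amide carrying a hydrogen can be active in this assay, while compound 3 carries none. The expectation for compound 4 is therefore a return to a measurable value, with a real chance that only inactivity is reported again. Compound 4 is estimated at 900 nM, within a range from 200 nM to 6000 nM.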

Compound 4, half-maximal effective concentration: "not active" (no number reported)
The entry for compound 4 holds no number; no gap can be computed for the estimate.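

In this assay compound 3 and compound 4 are both reported only as "not active", so no step can be read between them, and no evidence bears on this result. Left open is why compound 1 gives 476 nM while compound 3 and compound 4 give no number.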